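Swapping bromo for 3-methoxyphenyl on a shared core

The compounds below may be only part of what the source reports. "The series", "measured", "known", "first", "only" and "open" are said of these compounds alone.

In an ADME assay on Caco-2 cells (Homo sapiens) for permeability, read by LC-MS, in the apical to basolateral direction, with a stated time of 2 h, tested at 2 uM (a higher number here means that the compound crosses the layer faster, a lower number that the compound crosses the layer more slowly), compound 3 (`CC[C@@H](Nc1c(C#N)c(-c2ccc(Br)cc2)nc2cnccc12)C(N)=O`) gives 202 nm/s and compound 1 (`CC[C@@H](Nc1c(C#N)c(-c2ccc(-c3ccccc3F)cc2)nc2cnccc12)C(N)=O`) gives 140 nm/s, two values within the scatter of each other. Compound 2 (`CC[C@@H](Nc1c(C#N)c(-c2ccc(-c3cccc(Cl)c3F)cc2)nc2cnccc12)C(N)=O`) gives 39 nm/s, clearly apart from compound 3, so compound 3 stands in the upper group of this small set.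

The next structure, compound 4 (`CC[C@@H](Nc1c(C#N)c(-c2ccc(-c3cccc(OC)c3)cc2)nc2cnccc12)C(N)=O`), keeps the shared core and changes one place: 3-methoxyphenyl in place of bromo on an aromatic carbon. Put simply, 3-methoxyphenyl replaces bromo on an aromatic carbon.

Two measured steps exchange the same bromo for another substituted phenyl ring. The first, a 1.4-fold higher number from compound 1 to compound 3 (0.16 log units; within the scatter), stays within the scatter, while the second, a 5.2-fold higher number from compound 2 to compound 3 (0.71 log units; beyond the scatter), goes beyond it. Those two rings differ by one chloro, and a 3.6-fold lower number from compound 1 to compound 2 (0.56 log units; beyond the scatter) shows that this single addition moved the number beyond the scatter. Among the measured compounds shown here, compound 4 has a single substituent on its added ring, as compound 1 does, but no measured compound carries a methoxy group, so this comparison is only a rough guide.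

A modest fall is therefore expected in this assay, and the estimated change is a 1.8-fold lower number from compound 3 to compound 4 (0.26 log units; within the scatter). For compound 4 the expected value is 110 nm/s, with an estimated range of 40 nm/s to 230 nm/s.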

Compound 4, apparent permeability: 104 nm/s
Compound 4: middle estimate off by 1.1-fold (0.02 log units), on the high side; low and high end bracket the measured number.
By their numbers in this assay, from the lowest: compound 2; then compounds 4, 1 and 3 (each within the scatter of the next).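

In this assay, this position takes a methoxy-bearing ring without leaving the upper group: swapping bromo for 3-methoxyphenyl gives a 1.9-fold lower number from compound 3 to compound 4 (0.29 log units; within the scatter), and exchanging the 2-fluorophenyl ring for 3-methoxyphenyl gives a 1.3-fold lower number from compound 1 to compound 4 (0.13 log units; within the scatter), so two different singly substituted rings and the bromo cannot be told apart here. Only the ring with two substituents stands apart, as a 2.7-fold higher number from compound 2 to compound 4 (0.43 log units; beyond the scatter) shows, and compound 4 now gives that separation a second reference point alongside compound 1, although three rings are too few to call it a rule. No measurement shown here explains why these numbers fall as they do.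

Going by these compounds, whether one more chloro on the ring of compound 4 would bring a drop like a 3.6-fold lower number from compound 1 to compound 2 (0.56 log units; beyond the scatter) remains open, since that drop has so far been seen on one ring only. Also open, on these data alone, is whether the number would hold in this range if the added ring carried an amine or a carboxylic acid in place of the methoxy group.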